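One Added Methyl on a Slowly Cleared Amide

This account rests on a few compounds, and the source may have more. Where it says the series, first, only, none or still open, it means among the compounds named here.

Among the compounds with values here, in an ADME assay on microsomes from liver (Homo sapiens) for metabolic stability, read by LC-MS, using NADPH, with stated times of 10 min and 30 min (on this read-out higher numbers stand for fast clearance and lower numbers for slow clearance), compound 1 (`CC(=O)N[C@@H]1CCCc2c1cncc2N1CCc2cc(Cl)ccc2C1=O`) gives 4.3 mL/min/kg which is the only exact number so far. Compound 2 (`CC[C@@H]1c2cc(Cl)ccc2C(=O)N1c1cncc2c1CCC[C@H]2NC(C)=O`) gives < 3.5 mL/min/kg which is a limit of the assay and not a number. Compound 3 (`CCC(=O)N[C@@H]1CCCc2c1cncc2N1CCc2cc(Cl)ccc2C1=O`) differs from compound 1 by methyl in place of hydrogen on a saturated chain carbon bound to a carbonyl carbon (acetamido to propanoylamino). Within the data shown here, no measured pair shows this change, so the expected step of a 1.2-fold higher number from compound 1 to compound 3 (0.07 log units; within the scatter) is small, estimated to lean slightly upward and to stay within the usual scatter. For compound 3 the estimate in this assay is 5 mL/min/kg with 3.5 mL/min/kg to 9 mL/min/kg as the expected range.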

Compound 3, clearance: < 3.5 mL/min/kg
Compound 3: only a limit was reported; the forecaster's own chance of this, stated with the estimate: 20%; middle value at least 1.4-fold (0.15 log units) from the limit.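

In this assay, the change from acetamido to propanoylamino gives an at least 1.2-fold lower number from compound 1 to compound 3 (0.08 log units; that floor lies within the scatter). The result for compound 3 is a limit of the assay and not a number, so the true size of this step cannot be read, but the added methyl brings no visible rise in clearance. Further differences at this slow end of the scale are hard to see: the limit of < 3.5 mL/min/kg in this assay, at which 2 of the 3 values shown sit.

As far as these compounds go, how far the clearance of compound 3 really lies from that of compound 1 stays open. Also open, from the compounds shown here alone, is whether a longer chain or an amine on this saturated chain carbon would keep clearance as slow.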